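The source may hold more compounds than are shown below. What is called first, only, known or untested is meant among the compounds shown, and "the series" means these compounds.

Measured compounds:
- compound 1 `N#CC1=C(N)Oc2c(c3nc4ccccc4nc3c3ccccc23)C12C(=O)N(Cc1cnnn1-c1ccc(F)cc1)c1ccccc12`: in a functional assay on HCT-116 cells (Homo sapiens) for antiproliferative activity, read by MTT assay, with a stated time of 48 h (a lower number here means a stronger inhibitor, a higher number a weaker inhibitor), compound 1 gives > 50000 nM, a limit of the assay and not a number.
- compound 2 `Cc1ccc(-n2nncc2CN2C(=O)C3(C(C#N)=C(N)Oc4c3c3nc5ccccc5nc3c3ccccc43)c3ccccc32)cc1Cl`: in this assay compound 2 gives > 50000 nM, again a limit of the assay.

Compound 2 therefore stands at the ceiling of what this assay reports; both values shown sit there (the limit of > 50000 nM in this assay, at which 2 of the 2 values shown sit). Within the data shown here, the one measured step, a step that the two limits leave unreadable from compound 1 to compound 2, touches the group on the aromatic nitrogen and stays unreadable between the two limits.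

Compound 3 `N#CC1=C(N)Oc2c(c3nc4ccccc4nc3c3ccccc23)C12C(=O)N(Cc1cnnn1-c1ccc(Cl)c(Cl)c1)c1ccccc12` differs from compound 2 by chloro in place of methyl on an aromatic carbon. Among the measured compounds shown here, no measured step bears on this position, and the one step there is cannot be sized, so nothing beyond the scatter can be read for this assay in either direction. With compound 2 at its limit, the step expected is a step that the limit leaves unreadable from compound 2 to compound 3, which is none beyond the scatter. For compound 3 the expected value in this assay is 60000 nM, within 20000 nM to 200000 nM, most probably reported as a limit again.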

Compound 3, half-maximal inhibitory concentration: > 50000 nM
Compound 3: a limit, no number (the forecaster's own chance of this, stated with the estimate: 85%); the middle value does not contradict the limit.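

In this assay compound 3 gives > 50000 nM, a limit of the assay and not a number. No step among compound 1, compound 2 and compound 3 can be read: the limit of > 50000 nM in this assay, at which 3 of the 3 values shown sit.

The compounds shown leave open whether any substituent on this aryl group moves activity in this assay at all.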